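Adding a methyl to the pyridine of compound 1

This account rests on a few compounds, and the source may have more. Where it says the series, first, only, none or still open, it means among the compounds named here.

Among the compounds with values here, compound 1 `Fc1cc2nc(-c3cccnc3)n(C3CC3)c2cc1F` holds the only number among the three values shown: in an assay on V79 cells for inhibition of cytochrome P450 11B1, mitochondrial (Homo sapiens), read by HTRF, with a stated time of 1 h (on this read-out lower numbers stand for stronger inhibition and higher numbers for weaker inhibition), compound 1 gives 370 nM. Compound 2 `c1cncc(-c2nc3ccccc3n2C2CC2)c1` reaches only a limit in this assay, > 8330 nM. Compound 3 `Fc1cccc2nc(-c3cccnc3)n(C3CC3)c12` likewise reaches only a limit, > 10000 nM. Within the data shown here, the single one-place step among the measured compounds, fluoro in place of hydrogen on an aromatic carbon, is a step that the two limits leave unreadable from compound 2 to compound 3. Compound 4 `Cc1ccncc1-c1nc2cc(F)c(F)cc2n1C1CC1` differs from compound 1 by methyl in place of hydrogen on an aromatic carbon. Among the measured compounds shown here, no measured step touches the pyridin-3-yl part, and the one measured step sits between two limits. Compound 4 is therefore expected to show a step of a 1.1-fold higher number from compound 1 to compound 4 (0.03 log units; within the scatter), not beyond the scatter. Compound 4 is estimated at 400 nM, between 100 nM and 1600 nM.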

Compound 4, half-maximal inhibitory concentration: 723 nM
For compound 4 the middle estimate is 1.8-fold (0.26 log units) below the measured one; the range from low to high includes it.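

Across the change from pyridin-3-yl to 4-methylpyridin-3-yl, this assay gives the first step in this series with a number at both ends, a 2.0-fold higher number from compound 1 to compound 4 (0.29 log units; within the scatter), and the earlier step could not be read. This place on the pyridine, ortho to a large group and opposite the ring nitrogen, therefore carries a methyl with no step beyond the scatter. Nothing shown here bears on why the step has this size. The compounds shown leave open whether an ethyl, a methoxy or an amine at this place would also stay within the scatter. They also leave open how a methyl would read elsewhere on the pyridine.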